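Hexylamino in place of benzylsulfanyl on the shared core

The source may hold more compounds than are shown below. What is called first, only, known or untested is meant among the compounds shown, and "the series" means these compounds.

Three compounds have been run through a functional assay on EL4 cells (Mus musculus) for inhibition, tested at 100 uM; on this read-out higher numbers stand for more inhibition at the one concentration tested (going by the name of the read-out) and lower numbers for less inhibition. Compound 1 `c1ccc(CNc2[nH]ccc3ncnc2-3)cc1` gives 57%. For compound 2 `OC[C@H]1O[C@@H](n2cnc3c(S)nccc32)C[C@@H]1O` the result of < 5% is a limit of the assay rather than a number (the limit of < 5% in this assay, at which 1 of the 3 values shown sits). Compound 3 `OC[C@H]1OC(n2cnc3c(SCc4ccccc4)nccc32)[C@H](O)[C@@H]1O` gives 30%, the lower of the two numbers obtained and well apart from compound 1. Compound 4 `CCCCCCNc1nccc2c1ncn2C1O[C@H](CO)[C@@H](O)[C@H]1O` has not been measured; it differs from compound 3 in one place: hexylamino in place of benzylsulfanyl on an aromatic carbon. Among the compounds with values here, no step between two measured compounds is available, so any expectation rests on the values alone. Compound 1 gives 57%, and on that basis a modest rise is expected, a number 8 percentage points higher from compound 3 to compound 4 (within the scatter). Compound 4 is therefore estimated at 38%, with a range from 12% to 62%.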

Compound 4, a percentage reported as inhibition, at one concentration (the size of the read-out at that concentration, not a potency): 14%
Beside the measured number, compound 4's estimate is 24 percentage points above it, and the stated range covers the measured number.
By their numbers in this assay, from the lowest: compound 4; then compound 3; then compound 1. At a limit, below all of these: compound 2.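

On the shared core, hexylamino in place of benzylsulfanyl gives a number 16 percentage points lower from compound 3 to compound 4 (beyond the scatter) in this assay, so this position is not indifferent to the group it carries. The change replaces the sulfur link and the aromatic ring together, and the step cannot tell their contributions apart. Nothing in the data shown explains the fall.

Open, on these data alone, is whether a hexylsulfanyl group at this position would stay nearer compound 3 or compound 4. Also open, as far as these compounds go, is how a shorter chain or a cyclohexylamino group would fare here.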